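Agonist Emax notes: sulfonyl-to-nitrile swap on the shared core

A few compounds are considered here, and "the series" means these few. Any claim that something is new, unique, unknown or untested is made for them only; others in the source may bear on it.

Measured so far:
- compound 1 `CC(C)(C)OC(=O)N1CCC(O[C@H]2CC[C@H](Oc3ccc(C#N)cc3)CC2)CC1`: 106%
- compound 2 `CC(C)S(=O)(=O)c1cnc(O[C@H]2CC[C@H](OC3CCN(C(=O)OC(C)(C)C)CC3)CC2)cn1`: 128%

Both compounds were run in a functional assay on isolated protein for agonist activity at Glucose-dependent insulinotropic receptor (Rattus norvegicus), read by HTRF and cAMP accumulation; a lower number here means a smaller maximal response, a higher number a larger maximal response. Compound 1 gives 106%, while compound 2 gives 128%. Compound 2 thus stands highest of the two numbers, and its nearest neighbour, compound 1, sits a gap lower that lies beyond the usual scatter of the measurement. Among the compounds with values here, no pair of measured compounds differs in only one place, so no measured step is available to set a scale for a single change.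

The next compound, compound 3 `CC(C)(C)OC(=O)N1CCC(O[C@H]2CC[C@H](Oc3cnc(C#N)cn3)CC2)CC1`, departs from compound 2 by one change: cyano in place of isopropylsulfonyl on an aromatic carbon. Within the data shown here, the only other nitrile-bearing compound in the set, compound 1, gives the lower of the two values, but its core differs from that of compound 3 in more than one place, so nothing beyond its value can be read from it.

For compound 3 a step of a number 18 percentage points lower from compound 2 to compound 3 (beyond the scatter) is expected, a fall that may reach beyond the scatter but is uncertain in size. The maximal response of compound 3 in this assay is estimated at 110%, with a range from 88% to 132%.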

Compound 3, largest response reached (Emax), in percent of the reference or control that the assay uses: 100%
For compound 3 the middle estimate is 10 percentage points above the measured one; the range from low to high includes it.
By their numbers in this assay, from the lowest: compounds 3 and 1 (each within the scatter of the next); then compound 2.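

In this assay, within the data shown here, cyano in place of isopropylsulfonyl on an aromatic carbon gives a number 28 percentage points lower from compound 2 to compound 3 (beyond the scatter), the only single-place reading so far for this position and a sign that maximal response depends on the group held there. With the nitrile kept and the aromatic ring changed, 5-cyanopyrazin-2-yl in place of 4-cyanophenyl gives a number 6 percentage points lower from compound 1 to compound 3 (within the scatter), so this pair shows no separable effect of that ring change, and the nitrile-bearing compounds stay together below compound 2 in this small set. No measurement bearing on the reason for either step is available.

The compounds shown leave open whether a methylsulfonyl group, a carboxamide or an amine on the same aromatic carbon would read closer to compound 2 or to compound 3, and so whether the higher response goes with the sulfonyl group as such or with the isopropylsulfonyl group in particular. They also leave open whether an isopropylsulfonyl group on the ring of compound 1 would give a step of similar size, and whether the step would persist with an isopropyl carbamate in place of the tert-butyl carbamate.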